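From compound 3 to compound 4: one double bond fewer

This account rests on a few compounds, and the source may have more. Where it says the series, first, only, none or still open, it means among the compounds named here.

Compound 1 `Clc1cccc2c1CC2CCN1CCN(c2cccc3c2OCCO3)CC1`: 1.25 mg/kg
Compound 2 `c1ccc2c(c1)CC2CCCCN1CCN(c2cccc3c2OCCO3)CC1`: 5 mg/kg
Compound 3 `C1=C(CCN2CCN(c3cccc4c3OCCO4)CC2)c2ccccc2C1`: 0.63 mg/kg

These three compounds share one core and differ in the group carried on the saturated chain carbon two bonds along the chain from an amine nitrogen in a ring, and in the length of that chain. In a functional assay on the whole organism for antagonist activity, with Rattus norvegicus as the target (a lower number here means that less compound is needed, a higher number that more compound is needed for the effect), compound 3 gives 0.63 mg/kg, the lowest number of the three; compound 1 sits nearest to it, within the scatter, while compound 2 shows a higher number that lies beyond the scatter.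

Compound 4 `c1ccc2c(c1)CCC2CCN1CCN(c2cccc3c2OCCO3)CC1` differs from compound 3 in one place: a group of 9 heavy atoms (9 carbon; one five-membered non-aromatic ring of carbon only, one six-membered aromatic ring of carbon only) in place of a group of 9 heavy atoms (9 carbon; one five-membered non-aromatic ring of carbon only, one six-membered aromatic ring of carbon only), on a saturated chain carbon, two bonds along the chain from an amine nitrogen in a ring. The group that leaves carries 1 double bond outside aromatic rings; the 2,3-dihydro-1H-inden-1-yl group that enters does not.

Going by the values given here, only one measured step bears on a swap of this group at this place, a 2.0-fold lower number from compound 1 to compound 3 (0.30 log units; within the scatter), and it lay within the scatter. Among the compounds with values here, nothing among the measured compounds separates the saturated from the unsaturated five-membered non-aromatic ring. Compound 4 is therefore expected to stay close to compound 3, with a step of a 1.3-fold higher number from compound 3 to compound 4 (0.10 log units; within the scatter) that is expected to fall within the scatter. The estimate for compound 4 in this assay is 0.8 mg/kg, with a range from 0.3 mg/kg to 2.5 mg/kg.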

Compound 4, minimum effective dose: 0.63 mg/kg
Compound 4: middle estimate off by 1.3-fold (0.10 log units), on the high side; the measured number falls inside the stated range.
By their numbers in this assay, from the lowest: compounds 3, 4 and 1 (each within the scatter of the next); then compound 2.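

In this assay, the loss of the double bond outside aromatic rings gives no change at the digits printed from compound 3 to compound 4 (within the scatter), so on a saturated chain carbon, two bonds along the chain from an amine nitrogen in a ring, the measurements do not separate the saturated five-membered ring from the unsaturated one. The 2,3-dihydro-1H-inden-1-yl group also gives a 2.0-fold lower number from compound 1 to compound 4 (0.30 log units; within the scatter) when it takes the place of the chlorine-bearing group with its four-membered ring, so a second group with a five-membered ring now gives a step within the scatter at this place, as the unsaturated one did before it. No supporting measurement is available to explain either step.

From the compounds shown here alone, whether this tolerance extends to a group that brings in a heteroatom, such as a hydroxyl or an amine on the 2,3-dihydro-1H-inden-1-yl group, remains open. Also open, going by these compounds, is how a longer chain would behave with the 2,3-dihydro-1H-inden-1-yl group in place, since compound 2 carries a longer chain but also differs from compound 4 in its ring group and so cannot settle the effect of chain length alone.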